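The source may report more compounds than this note shows. Statements on the series, on what has been measured and on what is new or still open speak of the compounds shown alone.

Compound 2 `COc1cccc(-c2c(C)n(Cc3c(F)cccc3F)c(=O)n(C[C@H](NC(C)C)C3CCCC3)c2=O)c1F` gives the lowest of the two numbers measured in an assay on HEK293 cells for binding affinity to Gonadotropin-releasing hormone receptor (Homo sapiens), read by radioligand binding; on this read-out lower numbers stand for stronger inhibition and higher numbers for weaker inhibition: compound 2 gives 12 nM, while compound 1 `COc1cccc(-c2c(C)n(Cc3c(F)cccc3F)c(=O)n(C[C@@H](N)CCc3ccccc3)c2=O)c1F` gives 965 nM. Among the compounds with values here, the single measured step, an 80-fold lower number from compound 1 to compound 2 (1.91 log units; beyond the scatter), altered both the amine and the chain at once. Compound 3 `COc1cccc(-c2c(C)n(Cc3c(F)cccc3F)c(=O)n(C[C@@H](N)CC(C)C)c2=O)c1F` carries the change (1-amino-3-methylbutyl in place of cyclopentyl(isopropylamino)methyl on a saturated chain carbon bound to an aromatic nitrogen), which returns to the plain amine seen in compound 1 but with a shorter chain. Because the step of an 80-fold lower number from compound 1 to compound 2 (1.91 log units; beyond the scatter) was large, compound 3 is expected to bind more weakly, by about a 17-fold higher number from compound 2 to compound 3 (1.22 log units; beyond the scatter). The estimate for compound 3 is 200 nM, with a range from 40 nM to 1000 nM.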

Compound 3, inhibition constant: 39 nM
Estimate against measurement, compound 3: 5.1-fold (0.71 log units) above; measured number below the stated range.
By their numbers in this assay, from the lowest: compound 2; then compound 3; then compound 1.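

In this assay, the plain amine remains compatible with a low number: a 3.3-fold higher number from compound 2 to compound 3 (0.51 log units; beyond the scatter) is only modest, even though 1-amino-3-methylbutyl replaces cyclopentyl(isopropylamino)methyl. Among the plain amines, the end of the chain has a large effect, with a 25-fold lower number from compound 1 to compound 3 (1.39 log units; beyond the scatter) when isopropyl replaces benzyl. No measured evidence here explains either shift. Still unresolved is how much of the difference in the first step belongs to the cyclopentyl ring and how much to the isopropyl group on the nitrogen. As far as these compounds go, a cyclohexyl group or a tert-butyl group at the chain end also remains open.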